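Hydroxamate amino acids against CSK: arginine to lysine side chain

The source may report more compounds than this note shows. Statements on the series, on what has been measured and on what is new or still open speak of the compounds shown alone.

Compound 1 `N=C(N)NCCC[C@H](N)C(=O)NO` in an assay on isolated protein for inhibition of tyrosine-protein kinase CSK (Homo sapiens), tested at 25 uM, in the presence of a further agent that is not named here (on this read-out lower numbers stand for less inhibition and higher numbers for more inhibition at the one concentration tested (going by the name of the read-out)), gives 0%. For the measured compounds named here, compound 2 `N[C@@H](CCC(=O)NO)C(=O)O` in this assay gives 0%, level with compound 1 within the scatter, and no step between the pair is counted. Compound 3 `NCCCC[C@H](N)C(=O)NO` awaits measurement. Compound 3 differs from compound 1 as follows: a group of 2 heavy atoms (1 carbon, 1 nitrogen; no ring) in place of a group of 4 heavy atoms (1 carbon, 3 nitrogen; no ring), on a saturated chain carbon, four bonds along the chain from an amine nitrogen and a carbonyl carbon. Because compound 1 gives 0% and compound 2 gives 0%, the expected step of no change at the digits printed from compound 1 to compound 3 (within the scatter) is none beyond the scatter. Compound 3 is therefore estimated at 0%, with a range from 0% to 10%.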

Compound 3, a percentage reported as inhibition, at one concentration (the size of the read-out at that concentration, not a potency): 3%
Beside the measured number, compound 3's estimate is 3 percentage points below it; the range from low to high includes it.
By their numbers in this assay, from the lowest: compounds 1, 2 and 3 (each within the scatter of the next).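

Swapping the group of 4 heavy atoms for aminomethyl at this saturated chain carbon gives a number 3 percentage points higher from compound 1 to compound 3 (within the scatter). In this assay, this change of side-chain end therefore shows no effect beyond the scatter, and all three compounds stay close to the bottom of the read-out. Nothing available bears on a cause for this result.

On these data alone, whether any group at this place can raise the read-out beyond the scatter remains open. A longer chain ending in an amine, or a carboxylic acid at the same carbon, would test this.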